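The compounds below may be only part of what the source reports. "The series", "measured", "known", "first", "only" and "open" are said of these compounds alone.

Measured in a physicochemical assay for lipophilicity, read by HPLC, measured as octanol-water partition, at pH 7.4; a higher number here means a more lipophilic compound, a lower number a more polar compound:
- compound 1 `CC1(C)C[C@@H](CN([C@H](CCC(F)(F)F)C(N)=O)S(=O)(=O)c2ccc(Cl)cc2)O1`: 3.8
- compound 2 `NC(=O)[C@@H](CCC(F)(F)F)N(C[C@@H]1CCOC1)S(=O)(=O)c1ccc(Cl)cc1`: 2.8

Compound 2 is the lower of the two. Compound 3 `NC(=O)[C@@H](CCC(F)(F)F)N(C[C@H]1CCO1)S(=O)(=O)c1ccc(Cl)cc1` is still unmeasured and differs from compound 2 as follows: oxetan-2-yl in place of oxolan-3-yl on a saturated chain carbon bound to a sulfonamide nitrogen. In words, this puts oxetan-2-yl in place of oxolan-3-yl on a saturated chain carbon bound to a sulfonamide nitrogen. For the measured compounds named here, only one measured step bears on this, a number 1.00 log units lower from compound 1 to compound 2 (beyond the scatter), at the same place but with a different exchange. A smaller downward move is therefore expected in this assay, and it may stay within the scatter. The expected step is a number 0.30 log units lower from compound 2 to compound 3 (within the scatter). For compound 3 the estimate is 2.5, with an expected range of 2.1 to 2.9.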

Compound 3, distribution coefficient: 2.6
Compound 3: the middle estimate sits 0.10 log units below what was measured, within the range that was stated.
By their numbers in this assay, from the lowest: compounds 3 and 2 (each within the scatter of the next); then compound 1.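

In this assay the exchange of oxolan-3-yl for oxetan-2-yl on this saturated chain carbon gives a number 0.20 log units lower from compound 2 to compound 3 (within the scatter) and so does not separate the five-membered ring from the four-membered ring. Removing the two methyl groups of 4,4-dimethyloxetan-2-yl gives a number 1.20 log units lower from compound 1 to compound 3 (beyond the scatter) and, among these three compounds, the clear separation lies with that substitution rather than with ring size. Nothing on hand gives a reason for either step. Open, on these data alone, is how an amine or a carboxylic acid at this place would read in this assay and whether these steps hold on another core.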